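The compounds below may be only part of what the source reports. "The series", "measured", "known", "first", "only" and "open" are said of these compounds alone.

Measured in an ADME assay on Huh-7 cells (Homo sapiens) for cytotoxicity, with a stated time of 3 days; on this read-out higher numbers stand for lower toxicity in this test and lower numbers for higher toxicity in this test:
compound 1 `O=C(Nc1ccccc1)c1c(NO)cc(-c2cccs2)oc1=O`, reported only as the limit > 20000 nM.
compound 2 `Cc1ccc(NC(=O)c2c(NO)cc(-c3cccs3)oc2=O)cc1`, reported only as the limit > 20000 nM.

Compound 2 stands at the limit of this assay, and so does the other measured compound: both values sit at the limit of > 20000 nM in this assay, at which 2 of the 2 values shown sit, so neither compound carries a number. The step that the two limits leave unreadable from compound 1 to compound 2 cannot be read, the two limits leaving its size open.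

Compound 3 `Nc1ccccc1NC(=O)c1c(NO)cc(-c2cccs2)oc1=O` differs from compound 2 by 2-aminophenyl in place of 4-methylphenyl on an amide-type nitrogen. Going by the values given here, the only measured step, a step that the two limits leave unreadable from compound 1 to compound 2, alters the same aromatic ring but gives no size, so nothing measured shows any effect in this assay from a change on this ring. With both measured compounds at the limit, compound 3 is expected to sit there as well. The step of a number no higher from compound 2 to compound 3 (the limit leaves the size open) is expected to be none beyond the scatter. Compound 3 is estimated at 20000 nM, between 8000 nM and 60000 nM, most likely reported again only as a limit.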

Compound 3, half-maximal cytotoxic concentration: > 20000 nM
Compound 3 was reported as a limit; the forecaster's own chance of this, stated with the estimate: 75%; the middle value lies on the limit itself.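

In this assay compound 3 is again reported only as a limit, and no step among compound 1, compound 2 and compound 3 can be read: the limit of > 20000 nM in this assay, at which 3 of the 3 values shown sit.

The compounds shown leave open whether any change on this aromatic ring alters cytotoxicity.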